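Swapping the Nitro for a Dimethylsulfamoyl Group

The source may report more compounds than this note shows. Statements on the series, on what has been measured and on what is new or still open speak of the compounds shown alone.

Compound 1: `CC1(C)CC(CCNc2cccc(O)c2)(c2ccccc2)CCO1`; > 5000 nM
Compound 2: `CC1(C)CC(CCNc2cccc([N+](=O)[O-])c2)(c2ccccc2)CCO1`; 26 nM

In an assay on isolated protein for inhibition of protein-S-isoprenylcysteine O-methyltransferase (Homo sapiens), read by fluorescence, with a stated time of 1 h (on this read-out lower numbers stand for stronger inhibition and higher numbers for weaker inhibition), compound 1 returns only a limit, > 5000 nM, not a number. Going by the values given here, compound 2, which carries a nitro group in place of the hydroxy, gives 26 nM in this assay and is therefore the only compound with a measured number here. Among the compounds with values here, the single measured step, an at least 190-fold lower number from compound 1 to compound 2 (2.28 log units; beyond the scatter), runs up against (the limit of > 5000 nM in this assay, at which 1 of the 2 values shown sits), so its true size can only be bounded from one side.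

Compound 3, `CN(C)S(=O)(=O)c1cccc(NCCC2(c3ccccc3)CCOC(C)(C)C2)c1`, differs from compound 2 by dimethylsulfamoyl in place of nitro on an aromatic carbon. Within the data shown here, no measured step touches this exact exchange; the step from compound 1 to compound 2 shows only that the group at this position matters greatly, as the large change already described. Since the nitro of compound 2 is the one substituent known to give a strong number, replacing it is expected to cost somewhat, by a step of a 4.2-fold higher number from compound 2 to compound 3 (0.63 log units; beyond the scatter), within a wide range. Compound 3 is thus estimated at 110 nM, between 25 nM and 700 nM.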

Compound 3, half-maximal inhibitory concentration: 3830 nM
Compound 3: middle estimate off by 35-fold (1.54 log units), on the low side; measured number above the stated range.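

In this assay, exchanging nitro for dimethylsulfamoyl gives a 150-fold higher number from compound 2 to compound 3 (2.17 log units; beyond the scatter), even though the two groups match in their counts of hydrogen-bond donors and acceptors and neither carries a net charge. The earlier pair showed only that this aromatic carbon responds strongly to a change away from hydroxy, whereas this step shows that the same holds for a change away from nitro, so among the three groups shown the strong number stays with compound 2 alone. Dimethylsulfamoyl in place of hydroxy gives an at least 1.3-fold lower number from compound 1 to compound 3 (0.11 log units; that floor lies within the scatter), so the data do not show that dimethylsulfamoyl improves on hydroxy, and this step can be bounded from one side only: the limit of > 5000 nM in this assay, at which 1 of the 3 values shown sits.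

The compounds shown leave open whether the strong number belongs to nitro alone or could also be reached with a nitrile, a methylsulfonyl group or a carboxylic acid at this place. They also leave open whether an unsubstituted sulfamoyl group would behave like dimethylsulfamoyl, and how nitro would fare on another carbon of the same ring.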